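Adding butyl chains to the amine of compound 3

The compounds below may be only part of what the source reports. "The series", "measured", "known", "first", "only" and "open" are said of these compounds alone.

Values in a functional assay on LNCaP cells (Homo sapiens) for antiproliferative activity, read by WST assay, with a stated time of 3 days; on this read-out lower numbers stand for stronger inhibition and higher numbers for weaker inhibition:
- compound 1 `CCCCCOc1c(-c2cc(OC)c(OC)c(OC)c2)oc2ccccc2c1=O`: 15400 nM
- compound 2 `CCCCCCCOc1c(-c2cc(OC)c(OC)c(OC)c2)oc2ccccc2c1=O`: > 50000 nM, a limit of the assay
- compound 3 `CCN(CC)CCCCCOc1c(-c2cc(OC)c(OC)c(OC)c2)oc2ccccc2c1=O`: 10000 nM

Compound 3 gives 10000 nM and compound 1 gives 15400 nM, so the two cannot be told apart. The gap is a 1.5-fold lower number from compound 1 to compound 3 (0.19 log units; within the scatter). Compound 4 `CCCCN(CCCC)CCCCCOc1c(-c2cc(OC)c(OC)c(OC)c2)oc2ccccc2c1=O` carries dibutylamino in place of diethylamino on a saturated chain carbon, five bonds along the chain from an oxygen on an aromatic ring. Two other steps bear on this change. Ethyl on that carbon gave an at least 3.2-fold higher number from compound 1 to compound 2 (0.51 log units; beyond the scatter), while diethylamino in place of ethyl gave an at least 5.0-fold lower number from compound 2 to compound 3 (0.69 log units; beyond the scatter). These pull in opposite directions, so no shift beyond the scatter is expected, and the expected step is a 1.1-fold lower number from compound 3 to compound 4 (0.05 log units; within the scatter). The estimate for compound 4 is 9000 nM, with an expected range of 2500 nM to 32000 nM.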

Compound 4, half-maximal inhibitory concentration: 7800 nM
Compound 4: the middle estimate sits 1.2-fold (0.06 log units) above what was measured; measured number inside the range.
By their numbers in this assay, from the lowest: compounds 4, 3 and 1 (each within the scatter of the next). At a limit, above all of these: compound 2.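

In this assay the longer butyl chains on the amine leave the number within the scatter (a 1.3-fold lower number from compound 3 to compound 4 (0.11 log units; within the scatter)), so at this position dibutylamino and diethylamino cannot be told apart. Dibutylamino in place of hydrogen also stays within the scatter (a 2.0-fold lower number from compound 1 to compound 4 (0.30 log units; within the scatter)), whereas dibutylamino in place of ethyl gives a step beyond it (an at least 6.4-fold lower number from compound 2 to compound 4 (0.80 log units; beyond the scatter)). That last step has only a lower bound, since compound 2 reads as a limit: the limit of > 50000 nM in this assay, at which 1 of the 4 values shown sits.

Open, on these data alone, is whether a smaller amine such as dimethylamino, a ring amine such as piperidine, or a carboxylic acid on that carbon would move the number beyond the scatter.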